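This account rests on a few compounds, and the source may have more. Where it says the series, first, only, none or still open, it means among the compounds named here.

Three sulfonamides sharing a core were tested in an assay on isolated protein for inhibition of malate dehydrogenase, mitochondrial (Sus scrofa), with stated times of 45 min and 30 min; a lower number here means a stronger inhibitor, a higher number a weaker inhibitor. Among the compounds with values here, compound 1 `O=S(=O)(Nc1ccc2oc(-c3ccccc3)nc2c1)c1ccc(Cl)c(Cl)c1` is the first of them. In this assay compound 1 gives > 63000 nM, which is a limit of the assay and not a number. Compound 2 `Cc1cccc(S(=O)(=O)Nc2ccc3oc(-c4ccccc4)nc3c2)c1` differs from compound 1 by 3-methylphenyl in place of 3,4-dichlorophenyl on a sulfonyl sulfur. In this assay compound 2 gives > 63000 nM, again only a limit. The step that the two limits leave unreadable from compound 1 to compound 2 therefore cannot be sized. Compound 3 `O=S(=O)(Nc1ccc(-c2nc3ccccc3o2)cc1)c1ccc(Cl)c(Cl)c1` has the same atoms as compound 1 joined differently; the difference between the two cores is not broken down here. In this assay compound 3 gives > 63000 nM, once more a limit. What the three share is the limit of > 63000 nM in this assay, at which 3 of the 3 values shown sit.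

Compound 4 `Cc1cccc(S(=O)(=O)Nc2ccc(-c3nc4ccccc4o3)cc2)c1` has not yet been measured in this assay. Within the data shown here, it differs from compound 3 by 3-methylphenyl in place of 3,4-dichlorophenyl on a sulfonyl sulfur, the same change, at the same place, as the one from compound 1 to compound 2. The step expected here is a step that the limit leaves unreadable from compound 3 to compound 4, and this expectation rests on a step that the two limits leave unreadable from compound 1 to compound 2, which left both values at the limit. Compound 4 is accordingly expected to give about 100000 nM in this assay, most likely reported only as a limit.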

Compound 4, half-maximal inhibitory concentration: > 63000 nM
Compound 4: only a limit was reported (the forecaster's own chance of this, stated with the estimate: 90%); the middle value does not contradict the limit.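

In this assay compound 4 gives > 63000 nM as a limit of the assay and not a number. Within the data shown here, compound 3 also stands only at a limit, so no step from compound 3 to compound 4 can be read. The compounds shown leave open whether any change to the sulfonyl group or the core would give a readable value, with all of them at one reading: the limit of > 63000 nM in this assay, at which 4 of the 4 values shown sit.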